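Removing the dimethylamino group from compound 3

The source may report more compounds than this note shows. Statements on the series, on what has been measured and on what is new or still open speak of the compounds shown alone.

Three measured compounds share one core and differ only in the aryl group attached to it. In a functional assay on MKN-45 cells (Homo sapiens) for inhibition, with a stated time of 72 h (on this read-out lower numbers stand for stronger inhibition and higher numbers for weaker inhibition), compound 1 `COc1ccc(S(=O)(=O)N2CCc3cccc(-c4cccnc4)c32)cc1` gives 68.5 nM, compound 2 `COc1ccc(S(=O)(=O)N2CCc3cccc(-c4ccc(F)c(F)c4)c32)cc1` gives 55.5 nM, and compound 3 `COc1ccc(S(=O)(=O)N2CCc3cccc(-c4ccc(N(C)C)cc4)c32)cc1` gives 237 nM, the highest of the three numbers. The steps of a 3.5-fold higher number from compound 1 to compound 3 (0.54 log units; beyond the scatter) and a 4.3-fold higher number from compound 2 to compound 3 (0.63 log units; beyond the scatter) both set compound 3 apart beyond the scatter. Compound 4 `COc1ccc(S(=O)(=O)N2CCc3cccc(-c4ccccc4)c32)cc1` differs from compound 3 by a single change: hydrogen in place of dimethylamino on an aromatic carbon. Both measured steps that bear on this change run against the compound carrying dimethylamino, so a lower number is expected for compound 4 in this assay, a 3.0-fold lower number from compound 3 to compound 4 (0.47 log units; beyond the scatter). Compound 4 is estimated at 80 nM, with a range from 30 nM to 220 nM.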

Compound 4, half-maximal inhibitory concentration: 117 nM
Compound 4: middle estimate off by 1.5-fold (0.17 log units), on the low side; the range from low to high includes it.
By their numbers in this assay, from the lowest: compounds 2, 1 and 4 (each within the scatter of the next, the first and the last beyond it); then compound 3.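

Compound 4 gives the series its bare phenyl reference, and in this assay taking dimethylamino off this aromatic carbon lowers the number (a 2.0-fold lower number from compound 3 to compound 4 (0.31 log units; beyond the scatter)). Fluorine on the ring also counts here, as 3,4-difluorophenyl stands apart from phenyl (a 2.1-fold higher number from compound 2 to compound 4 (0.32 log units; beyond the scatter)), whereas pyridin-3-yl and phenyl cannot be told apart (a 1.7-fold higher number from compound 1 to compound 4 (0.23 log units; within the scatter)). Nothing shown here explains these differences.

From the compounds shown here alone, it remains open whether a primary amine or a carboxylic acid at this place would behave like dimethylamino, and whether a single fluorine would match 3,4-difluorophenyl.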